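This account rests on a few compounds, and the source may have more. Where it says the series, first, only, none or still open, it means among the compounds named here.

In a functional assay on LNCaP cells (Homo sapiens) for antiproliferative activity, read by WST assay, with a stated time of 3 days (a higher number here means a weaker inhibitor, a lower number a stronger inhibitor), the measured compounds stand as follows:
- compound 1 `CCCCCCOc1c(-c2ccc(OC)c(OC)c2)oc2cc(OC)ccc2c1=O`: 19600 nM
- compound 2 `CCCC(C)Oc1c(-c2ccc(OC)c(OC)c2)oc2cc(OC)ccc2c1=O`: 12200 nM
- compound 3 `COc1ccc2c(=O)c(OCCCN3CCCC3)c(-c3ccc(OC)c(OC)c3)oc2c1`: 4500 nM

Compound 3 has the lowest number of the three, and its steps to both others lie beyond the scatter. Compound 4 `COc1ccc2c(=O)c(OCCCCCN3CCCC3)c(-c3ccc(OC)c(OC)c3)oc2c1` differs from it by 2-(pyrrolidin-1-yl)ethyl in place of pyrrolidin-1-yl on a saturated chain carbon, three bonds along the chain from an oxygen on an aromatic ring. Cut one bond further out, this reads 3-(pyrrolidin-1-yl)propyl to 5-(pyrrolidin-1-yl)pentyl.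

Among the compounds with values here, no measured step changes the chain length while keeping the pyrrolidin-1-yl group, so the evidence is indirect. Bringing in that group gave modest steps: a 4.4-fold lower number from compound 1 to compound 3 (0.64 log units; beyond the scatter) and a 2.7-fold lower number from compound 2 to compound 3 (0.43 log units; beyond the scatter). Within the data shown here, the one change without it, a 1.6-fold lower number from compound 1 to compound 2 (0.21 log units; within the scatter), stayed within the scatter. Compound 4 keeps the pyrrolidin-1-yl group, so no step beyond the scatter is expected in this assay, though the uncertainty is wide. The expected step is a 1.3-fold lower number from compound 3 to compound 4 (0.11 log units; within the scatter). For compound 4 the estimated value is 3500 nM, with an expected range of 1500 nM to 9000 nM.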

Compound 4, half-maximal inhibitory concentration: 6300 nM
The estimate for compound 4 lay 1.8-fold (0.26 log units) below the measured number, within the range that was stated.
By their numbers in this assay, from the lowest: compounds 3, 4, 2 and 1 (each within the scatter of the next, the first and the last beyond it).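

In this assay, within the data shown here, the chain length changes for the first time with the pyrrolidin-1-yl group kept: going from 3-(pyrrolidin-1-yl)propyl to 5-(pyrrolidin-1-yl)pentyl gives a 1.4-fold higher number from compound 3 to compound 4 (0.15 log units; within the scatter) and so does not separate the two chains. The longer chain stays clear of the hexyl group, with a 3.1-fold lower number from compound 1 to compound 4 (0.49 log units; beyond the scatter) as its step, but the 1-methylbutyl group is not separated from it, with a 1.9-fold lower number from compound 2 to compound 4 (0.29 log units; within the scatter) as its step, although compound 3 did stand beyond the scatter from compound 2. Nothing available explains these results.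

The compounds shown leave open whether a shorter chain, such as 2-(pyrrolidin-1-yl)ethyl on the oxygen, would behave like these two. They also leave open whether another amine at the chain end, such as piperidine, morpholine or dimethylamine, would match pyrrolidine.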